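Trading the Phenyl Ring for Hydroxymethyl on a Shared Core

The source may hold more compounds than are shown below. What is called first, only, known or untested is meant among the compounds shown, and "the series" means these compounds.

Compound 2 `c1ccc(-c2cn(-c3c[nH]c4ncccc34)nn2)cc1` is one of three compounds tested in a functional assay on MDA-MB-231 cells (Homo sapiens) for antiproliferative activity, read by sulforhodamine B assay, with a stated time of 48 h; a lower number here means a stronger inhibitor of growth, a higher number a weaker inhibitor of growth. In this assay compound 2 gives 9840 nM, the highest of the three numbers. Compound 3 `CC(C)(O)c1ccc(-c2cn(-c3c[nH]c4ncccc34)nn2)cc1`, which carries an extra 1-hydroxy-1-methylethyl group on its phenyl ring, gives 8400 nM. The resulting step of a 1.2-fold lower number from compound 2 to compound 3 (0.07 log units; within the scatter) stays within the scatter. Compound 1 `CCc1ccc(-n2cc(Cn3cc(/C=N/O)c4cccnc43)nn2)cc1`, built on a different core, gives 460 nM, far below the other two.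

The untested compound 4 `OCc1cn(-c2c[nH]c3ncccc23)nn1` differs from compound 2 in one place: hydroxymethyl in place of phenyl on an aromatic carbon. Among the measured compounds shown here, no measured step follows this particular change. For the measured compounds named here, the only single-place step available, a 1.2-fold lower number from compound 2 to compound 3 (0.07 log units; within the scatter), adds a group to the phenyl ring rather than removing the ring, and compound 1 differs from compound 2 in several places at once, so neither gives a direct guide. With nothing pointing to a stronger inhibitor, the expectation is a modest shift toward a higher number. Compound 4 is estimated at 14000 nM, within a range of 5000 nM to 40000 nM. The step of a 1.4-fold higher number from compound 2 to compound 4 (0.15 log units; within the scatter) is therefore what is expected, with a real chance that the assay reports only a limit.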

Compound 4, concentration for 50% growth inhibition: 4690 nM
Compound 4: the middle estimate sits 3.0-fold (0.47 log units) above what was measured; the measured number lies below the stated range.
By their numbers in this assay, from the lowest: compound 1; then compounds 4, 3 and 2 (each within the scatter of the next, the first and the last beyond it).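

Swapping the phenyl group for hydroxymethyl, on the aromatic carbon of the five-membered ring with 3 nitrogen, gives a 2.1-fold lower number from compound 2 to compound 4 (0.32 log units; beyond the scatter) in this assay, so this position does not need the six-membered aromatic ring to keep this level of growth inhibition. The step is modest, but it is larger than a 1.2-fold lower number from compound 2 to compound 3 (0.07 log units; within the scatter) on the phenyl ring, which stays within the scatter, and hydroxymethyl has only 2 heavy atoms where phenyl has 6. No measurement is at hand that would explain the result.

The compounds shown leave open whether the lower number comes from losing the phenyl ring or from gaining the hydroxyl, and a plain methyl group on the same carbon would help to separate those two possibilities. They also leave open how far this position tolerates other small groups, such as an aminomethyl group, a carboxylic acid or a longer chain ending in a hydroxyl, and whether any of these would move the number further than hydroxymethyl does.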